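The source may hold more compounds than are shown below. What is called first, only, known or untested is meant among the compounds shown, and "the series" means these compounds.

In an in vivo ADME assay on the whole organism (strain Sprague-Dawley) for pharmacokinetics, with Rattus norvegicus as the target, at a dose of 5 mg/kg by the oral route (a lower number here means that a smaller share of the oral dose reaches the circulation, a higher number that a larger share of the oral dose reaches the circulation), compound 1 `CON[C@]1(CCC(C)C)C(=O)C(C2=NS(=O)(=O)c3cc(NS(C)(=O)=O)ccc3N2)=C(O)c2ccccc21` stands at 34.1% and compound 3 `Cc1cccc(C)c1CNC1(CCC(C)(C)C)C(=O)C(C2=NS(=O)(=O)c3cc(NS(C)(=O)=O)ccc3N2)=C(O)c2ccccc21` at 53.7% while compound 2 `CC(C)CC[C@@]1(NCc2ccccc2)C(=O)C(C2=NS(=O)(=O)c3cc(NS(C)(=O)=O)ccc3N2)=C(O)c2ccccc21` comes in at 13.3% as the lowest of the three, beyond the scatter from both others. Attention now turns to compound 4 `CC(C)CC[C@@]1(N)C(=O)C(C2=NS(=O)(=O)c3cc(NS(C)(=O)=O)ccc3N2)=C(O)c2ccccc21` which has not yet been measured. The change from compound 2 to compound 4 is hydrogen in place of benzyl on an amine nitrogen and it amounts to hydrogen in place of benzyl on an amine nitrogen, or benzylamino to amino. Among the measured compounds shown here, only one measured step touches this nitrogen, benzyl in place of methoxy, and with benzyl now leaving, a number 20.8 percentage points lower from compound 1 to compound 2 (beyond the scatter) points to a move the other way in this assay of modest size. The comparison is imperfect, for hydrogen is not methoxy. For the measured compounds named here, compound 3 at 53.7% differs from compound 2 in more than one place and offers no clean step. An upward move beyond the scatter is therefore expected, estimated as a number 14.7 percentage points higher from compound 2 to compound 4 (beyond the scatter) with considerable doubt. For compound 4 the estimate is 28% with an expected range from 10% to 50% as the likely span.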

Compound 4, oral bioavailability: 0%
Estimate against measurement, compound 4: 28 percentage points above; the whole stated range lies above it.
By their numbers in this assay, from the lowest: compound 4; then compound 2; then compound 1; then compound 3.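

On the amine nitrogen whose other neighbour is a saturated ring carbon, hydrogen gives the lowest number of the three substituents compared in this assay, with a number 13.3 percentage points lower from compound 2 to compound 4 (beyond the scatter) and a number 34.1 percentage points lower from compound 1 to compound 4 (beyond the scatter). The earlier step had only ranked benzyl below methoxy, whereas compound 4 at 0% now shows that both substituted compounds stand above the free amino compound, so the loss seen with benzyl does not continue into a further loss-free direction when the group is removed: among compounds 1, 2 and 4, any substituent present on this nitrogen goes with a higher oral bioavailability than hydrogen, and none of the three goes against this. The data offer no measurement that accounts for this order.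

From the compounds shown here alone, it remains open whether a methyl group or an acetyl group on this nitrogen would stand with the substituted compounds or nearer to compound 4. Compound 3 at 53.7% differs from compound 2 in more than one place, so the contributions of its longer chain and of the two methyl groups on its benzyl ring cannot be separated.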